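The compounds below may be only part of what the source reports. "The series", "measured", "known", "first", "only" and "open" are said of these compounds alone.

Working notes on the series. Three compounds have been run in a physicochemical assay for lipophilicity, read by NMR (a lower number here means a more polar compound, a higher number a more lipophilic compound), so far. Compound 1 `CC(F)CCCO` gives 0.52 in this assay, and compound 3 `OCCCC(F)C(F)F` gives 0.52. Compound 2 `CC(=O)N1CCC[C@H]1C(=O)OCC(F)F` gives 0.02, the lowest of the three, with both other numbers beyond the scatter above it. Compound 3 and compound 1 differ in one place, (methyl in place of difluoromethyl on a saturated chain carbon bound to a fluorine atom and a saturated chain carbon), and that change made no change at the digits printed from compound 3 to compound 1 (within the scatter).

Compound 4 `CCOC(=O)[C@@H]1CCCN1C(C)=O` has not yet been measured. It differs from compound 2 by methyl in place of difluoromethyl on a saturated chain carbon bound to an oxygen next to a carbonyl group. This is the same kind of change as that from compound 3 to compound 1, not the same change: there the place was a saturated chain carbon bound to a fluorine atom and a saturated chain carbon, here it is a saturated chain carbon bound to an oxygen next to a carbonyl group. The difference between the cores of compound 2 and compound 3 is not broken down here.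

Among the compounds with values here, the step from compound 2 to compound 4 is expected to be a number 0.03 log units higher from compound 2 to compound 4 (within the scatter), resting on the single precedent no change at the digits printed from compound 3 to compound 1 (within the scatter) seen from compound 3 to compound 1. In this assay compound 4 is therefore estimated at 0.05, with a range from -0.3 to 0.4.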

Compound 4, partition coefficient: 0
Compound 4: middle estimate off by 0.05 log units, on the high side; the measured number falls inside the stated range.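

In this assay, methyl in place of difluoromethyl gives a number 0.02 log units lower from compound 2 to compound 4 (within the scatter), and the same kind of change on the other core gives no change at the digits printed from compound 3 to compound 1 (within the scatter), so in both pairs shown the step stays within the scatter. This shows agreement across two cores and two different places, a saturated chain carbon bound to a fluorine atom and a saturated chain carbon in one and a saturated chain carbon bound to an oxygen next to a carbonyl group in the other, but two pairs do not establish a rule for further cores in the series. Nothing measured here bears on why the step is this size in either pair.

The compounds shown leave open whether the step stays within the scatter on a core carrying an amine or a carboxylic acid. They also leave open how trifluoromethyl, or a longer chain such as propyl, would compare at the same place.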